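Cyano in place of fluoro on a nitrofuran amide

The compounds below may be only part of what the source reports. "The series", "measured", "known", "first", "only" and "open" are said of these compounds alone.

Measured so far:
Compound 1, `CC(C)(NC(=O)c1ccc([N+](=O)[O-])o1)c1ccccc1`, in an ADME assay on Vero cells (Chlorocebus sabaeus) for cytotoxicity, read by MTT assay, with a stated time of 48 h; a higher number here means that more compound is tolerated, a lower number that less compound is tolerated: > 180000 nM
Compound 2, `CC(C)(NC(=O)c1ccc([N+](=O)[O-])o1)c1ccc(F)cc1`, in this assay: 42000 nM

Compound 1 shows only a limit in this assay, > 180000 nM. For the measured compounds named here, compound 2 gives 42000 nM, the one definite number so far. The other value is a limit (the limit of > 180000 nM in this assay, at which 1 of the 2 values shown sits). Going by the values given here, the one measured step is an at least 4.2-fold lower number from compound 1 to compound 2 (0.63 log units; beyond the scatter). Compound 3, `CC(C)(NC(=O)c1ccc([N+](=O)[O-])o1)c1ccc(C#N)cc1`, differs from compound 2 by cyano in place of fluoro on an aromatic carbon. Among the compounds with values here, no measured step exchanges one substituent for another on that aromatic carbon; the step from compound 1 to compound 2 introduces a substituent where there was hydrogen. Nothing measured therefore bears directly on the cyano-for-fluoro change, and no step beyond the scatter is expected in this assay. Compound 3 is expected near 55000 nM, between 18000 nM and 180000 nM, a step of a 1.3-fold higher number from compound 2 to compound 3 (0.12 log units; within the scatter) from compound 2.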

Compound 3, half-maximal cytotoxic concentration: 83000 nM
For compound 3 the middle estimate is 1.5-fold (0.18 log units) below the measured one; measured number inside the range.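

In this assay the exchange of one substituent for another on this aromatic carbon gives a 2.0-fold higher number from compound 2 to compound 3 (0.30 log units; within the scatter), so fluoro and cyano are not separated here. Set against hydrogen, cyano gives an at least 2.1-fold lower number from compound 1 to compound 3 (0.33 log units; beyond the scatter), which means that both substituents placed para to a large group, in compound 2 and compound 3, stand apart from the unsubstituted compound 1 while matching each other within the scatter. Compound 1 is held only by a limit, so the true size of both steps away from it stays unfixed: the limit of > 180000 nM in this assay, at which 1 of the 3 values shown sits.

The compounds shown leave open whether an amine, a carboxylic acid or a methoxy group at this place would fall with compound 2 and compound 3. They also leave open whether a substituent elsewhere on this ring would do the same.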